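A few compounds are considered here, and "the series" means these few. Any claim that something is new, unique, unknown or untested is made for them only; others in the source may bear on it.

Of the compounds shown here, three have so far been tested in a functional assay on the whole organism with Mus musculus as the target; a lower number here means a smaller maximal response, a higher number a larger maximal response. Compound 1 `C=CCn1c(=O)n(CCCCO)c2nc(N)nc(O)c21` gives 16% there, compound 2 `C=CCn1c(=O)n([C@H]2CO[C@@H](CO)C2)c2nc(N)nc(O)c21` gives 16%, and compound 3 `Cn1c(=O)n(C2OC(CO)[C@@H](O)[C@H]2O)c2nc(N)nc(O)c21` gives 100%. Among the compounds with values here, compound 2 stands level with compound 1, and the two of them together sit lowest of the three numbers, while compound 3 lies far higher; compound 3 differs from compound 2 in more than one place, so its value alone shows no single step.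

Compound 4 `C=CCn1c(=O)n(C2CCC(CO)C2)c2nc(N)nc(O)c21` differs from compound 2 by a group of 7 heavy atoms (6 carbon, 1 oxygen; one five-membered non-aromatic ring of carbon only) in place of a group of 7 heavy atoms (5 carbon, 2 oxygen; one five-membered non-aromatic ring with 1 hetero atom), on an aromatic nitrogen. Within the data shown here, the one step measured on this part of the molecule, no change at the digits printed from compound 1 to compound 2 (within the scatter), shows that exchanging one group for another on this aromatic nitrogen left the maximal response where it was. On that evidence the exchange of the ring here is also expected to produce no step beyond the scatter in this assay, and the step from compound 2 to compound 4 is estimated as a number 2 percentage points higher from compound 2 to compound 4 (within the scatter). Compound 4 is therefore expected to give about 18%, most likely between 5% and 40%.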

Compound 4, largest response reached (reported as maximal response), in percent of the reference or control that the assay uses: 0%
Estimate against measurement, compound 4: 18 percentage points above; the whole stated range lies above it.
By their numbers in this assay, from the lowest: compound 4; then compounds 1 and 2 (each within the scatter of the next); then compound 3.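

In this assay, the group on this aromatic nitrogen does matter: swapping the ring with one hetero atom for the ring of carbon only gives a number 16 percentage points lower from compound 2 to compound 4 (beyond the scatter), and replacing the open chain with that carbon ring gives a number 16 percentage points lower from compound 1 to compound 4 (beyond the scatter). The earlier pair alone showed no difference between a chain and a ring, whereas these steps show that two rings of the same size and heavy-atom count can differ beyond the scatter, with one hydrogen-bond acceptor fewer and no defined stereocentres on the entering group. Nothing measured here accounts for this drop.

On these data alone, compound 4 alters the ring hetero atom and the defined stereocentres together, so the contribution of each stays open. A ring carrying an amine nitrogen in place of that hetero atom, or a longer chain on this nitrogen, also remains unaddressed by the compounds shown.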